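Ortho Substituent Swap on the Phenyl Group of an Oxytocin Antagonist

The compounds below may be only part of what the source reports. "The series", "measured", "known", "first", "only" and "open" are said of these compounds alone.

Compound 3 `COc1ccccc1[C@H](C(=O)NC(C)C)N1C(=O)[C@@H](C2Cc3ccccc3C2)NC(=O)[C@H]1CC(C)C` gives 31.6 nM in an assay on isolated protein for antagonist activity at Oxytocin receptor (Homo sapiens), read by FLIPR (a lower number here means a stronger inhibitor, a higher number a weaker inhibitor), level with compound 1 `CC(C)C[C@@H]1C(=O)N[C@H](C2Cc3ccccc3C2)C(=O)N1[C@@H](C(=O)NC(C)C)c1ccccc1C(F)(F)F` at 31.6 nM and together the highest of the three numbers; compound 2 `CCc1ccccc1[C@H](C(=O)NC(C)C)N1C(=O)[C@@H](C2Cc3ccccc3C2)NC(=O)[C@H]1CC(C)C` gives 15.9 nM in this assay. Compound 4 `CC(C)C[C@@H]1C(=O)N[C@H](C2Cc3ccccc3C2)C(=O)N1[C@@H](C(=O)NC(C)C)c1ccccc1Cl` differs from compound 3 by chloro in place of methoxy on an aromatic carbon. For the measured compounds named here, the steps that bear on it, a 2.0-fold lower number from compound 1 to compound 2 (0.30 log units; within the scatter) and a 2.0-fold higher number from compound 2 to compound 3 (0.30 log units; within the scatter) and no change at the digits printed from compound 1 to compound 3 (within the scatter), all lie within the scatter, so exchanging one group at this aromatic carbon for another has so far moved this assay little. Compound 4 is therefore expected to stay close to compound 3, with an estimated step of a 1.3-fold lower number from compound 3 to compound 4 (0.10 log units; within the scatter). The estimate for compound 4 in this assay is 25 nM, with a range from 8 nM to 80 nM.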

Compound 4, inhibition constant: 3.98 nM
For compound 4 the middle estimate is 6.3-fold (0.80 log units) above the measured one, and the stated range ends above it.
By their numbers in this assay, from the lowest: compound 4; then compounds 2, 1 and 3 (each within the scatter of the next).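

For the compounds shown here, with chloro on this aromatic carbon, the compounds show a 7.9-fold lower number from compound 3 to compound 4 (0.90 log units; beyond the scatter) and a 4.0-fold lower number from compound 2 to compound 4 (0.60 log units; beyond the scatter) and a 7.9-fold lower number from compound 1 to compound 4 (0.90 log units; beyond the scatter) in this assay and so give the first steps at this position that clear the scatter. Methoxy, ethyl and trifluoromethyl remain within the scatter of one another, so this position is not indifferent to its group, and compound 4 alone stands apart as the strongest inhibitor of the four. No measurement here explains why chloro differs from the other three groups.

The compounds shown leave open whether fluoro or bromo at this carbon would match chloro, and whether chloro would have the same effect elsewhere on the ring.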